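The compounds below may be only part of what the source reports. "The series", "measured", "known", "first", "only" and "open" are said of these compounds alone.

Compound 1 `O=C1C=C(NCc2ccccc2)C(=O)c2c1nc1n2[C@H]2OC[C@@H](O)[C@H]2OC1` sits in the middle of three measured compounds: in a functional assay on MGC-803 cells (Homo sapiens) for inhibition, read by sulforhodamine B assay (on this read-out lower numbers stand for stronger inhibition and higher numbers for weaker inhibition), compound 1 gives 2670 nM, while compound 2 `COc1ccc(NC2=CC(=O)c3c(nc4n3[C@H]3OC[C@@H](O)[C@H]3OC4)C2=O)cc1` gives 2150 nM and compound 3 `O=C1C(NCc2ccccc2)=CC(=O)c2c1nc1n2[C@H]2OC[C@@H](O)[C@H]2OC1` gives 3490 nM, all three within the scatter of one another. The next compound, compound 4 `O=C1C=C(Nc2ccccc2)C(=O)c2c1nc1n2[C@H]2OC[C@@H](O)[C@H]2OC1`, differs from compound 1 only by phenyl in place of benzyl on an amine nitrogen. Within the data shown here, the one measured step that bears on an aryl-for-benzyl swap runs the other way: a 1.6-fold higher number from compound 2 to compound 3 (0.21 log units; within the scatter). On that basis the reverse exchange in compound 4 is expected to move the number little, if anything slightly downward, and not beyond the scatter: a 1.2-fold lower number from compound 1 to compound 4 (0.06 log units; within the scatter). Compound 4 is therefore estimated at 2300 nM, with a range from 1200 nM to 4500 nM.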

Compound 4, half-maximal inhibitory concentration: 1730 nM
Compound 4: the middle estimate sits 1.3-fold (0.12 log units) above what was measured; the measured number falls inside the stated range.
By their numbers in this assay, from the lowest: compounds 4, 2, 1 and 3 (each within the scatter of the next).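

The direct exchange of benzylamino to anilino on the core of compound 1 gives a 1.5-fold lower number from compound 1 to compound 4 (0.19 log units; within the scatter) in this assay. Among these compounds, this is the first reading of this change at this amine nitrogen, and it shows that the exchange of benzyl for phenyl here cannot be told apart from repeat-measurement scatter. Nothing available explains the result.

The compounds shown leave open whether a longer alkyl chain, a morpholine or a carboxylic acid on this nitrogen would shift the number beyond the scatter. They also leave open whether substituents on the phenyl ring of compound 4 would do so.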